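This account rests on a few compounds, and the source may have more. Where it says the series, first, only, none or still open, it means among the compounds named here.

Two compounds have so far been run in an ADME assay on microsomes from liver (Rattus norvegicus) for metabolic stability, with a stated time of 10 min; a lower number here means that less of the compound is left, a higher number that more of the compound is left. In this assay compound 1 `CCOc1nn2cc(-c3cc4ccccc4o3)nc2s1` gives 37%. Compound 2 `COc1cc(OCc2cccc(CCc3ccccc3)c2)c2cc(-c3cn4nc(OC)sc4n3)oc2c1` gives 68%, the higher of the two numbers, and its distance above compound 1 lies beyond the usual scatter. Compound 3 `COc1cc(OCc2cccc(COc3ccccc3)c2)c2cc(-c3cn4nc(OC)sc4n3)oc2c1` has not yet been measured; it differs from compound 2 by phenoxy in place of benzyl on a saturated chain carbon bound to an aromatic carbon. Among the measured compounds shown here, no measured pair shows a change of this kind, so there is no basis to expect a shift beyond the scatter. Compound 3 is expected to give 65%, between 45% and 85%. The step this estimate implies is a number 3 percentage points lower from compound 2 to compound 3 (within the scatter).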

Compound 3, percent of the compound remaining: 64%
Compound 3: the middle estimate sits 1 percentage points above what was measured, within the range that was stated.
By their numbers in this assay, from the lowest: compound 1; then compounds 3 and 2 (each within the scatter of the next).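

Putting phenoxy in place of benzyl on a saturated chain carbon bound to an aromatic carbon, which can also be read as phenoxymethyl for phenethyl, gives a number 4 percentage points lower from compound 2 to compound 3 (within the scatter) in this assay for this pair. So at this place, an oxygen atom in the chain leaves the read-out within the scatter, a point the earlier compounds could not show. From the compounds shown here alone, whether an amine, a carboxylic acid or a longer chain at the same place would behave alike stays open. What lies behind the close match stays open too, since no supporting measurement bears on it.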